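Chloro for hydrogen on two cores of an enone series

The compounds below may be only part of what the source reports. "The series", "measured", "known", "first", "only" and "open" are said of these compounds alone.

Compound 1 `O=C(/C(=C\c1cccc(Cl)c1Cl)SCc1ccc(Cl)cc1)c1ccc(Br)cc1` and compound 2 `O=C(/C(=C\c1cc(Cl)cc(Cl)c1Cl)SCc1ccc(Cl)cc1)c1ccc(Br)cc1` share one core; compound 2 carries chloro in place of hydrogen on an aromatic carbon. In a functional assay on DU-145 cells (Homo sapiens) for inhibition, read by trypan blue exclusion, with a stated time of 96 h (a higher number here means a weaker inhibitor of growth, a lower number a stronger inhibitor of growth), compound 1 gives 10000 nM, and compound 2 gives 1000 nM, so that a 10-fold lower number from compound 1 to compound 2 (1.00 log units; beyond the scatter). Compound 3 `O=C(/C(=C/c1ccc(Cl)cc1)Cc1ccc(Cl)cc1)c1ccc(Cl)cc1Cl` has a different core; the difference between the two cores is not broken down here. In this assay compound 3 gives 10000 nM, level with compound 1 at the digits given. Compound 4 `O=C(/C(=C/c1ccc(Cl)cc1)Cc1ccc(Cl)c(Cl)c1)c1ccc(Cl)cc1Cl` is compound 3 with chloro in place of hydrogen on an aromatic carbon. This is the same kind of change as from compound 1 to compound 2, but the surroundings differ: in compound 2 the new chloro sits meta to a chloro group, meta to a large group and para to a chloro group, whereas in compound 4 it sits ortho to a chloro group and meta to a large group, on a different core. Among the compounds with values here, the step is expected to be a 2.5-fold lower number from compound 3 to compound 4 (0.40 log units; beyond the scatter), smaller than the earlier one, since the single precedent rests on another core and another place. Compound 4 is estimated at 4000 nM, from 1500 nM to 12000 nM.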

Compound 4, concentration for 50% growth inhibition: 1000 nM
For compound 4 the middle estimate is 4.0-fold (0.60 log units) above the measured one; the measured number lies below the stated range.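

In this assay, chloro for hydrogen, here 4-chlorobenzyl to 3,4-dichlorobenzyl, gives a 10-fold lower number from compound 3 to compound 4 (1.00 log units; beyond the scatter), and the step on this core matches the earlier one on the other core: the same change on two cores in this assay, a 10-fold lower number (1.00 log units; beyond the scatter) from compound 1 to compound 2 and a 10-fold lower number (1.00 log units; beyond the scatter) from compound 3 to compound 4, 1.0-fold (0.00 log units) apart, within the scatter of two such steps. The change therefore carries across the two cores in these two pairs, with a step of the same size even though the new chloro stands in different surroundings on each core. This rests on one pair per core in one cell assay, so it sets no rule for the series, does not explain the match, and does not show that the same step would appear elsewhere on either core.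

Still open, going by these compounds, is whether fluoro, methyl, methoxy or an amine in place of the new chloro would give a step of this size on either core. Also open is whether chloro for hydrogen on the other aromatic rings of these compounds would follow the two steps seen here.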